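Shorter linker on a benzyl core: a projected step

The compounds below may be only part of what the source reports. "The series", "measured", "known", "first", "only" and "open" are said of these compounds alone.

Compound 1, `CC(C)[C@H](N)C(=O)OCCCOC1(c2ccc(Cl)cc2)c2ccccc2C(=O)N1Cc1ccc(Cl)cc1`, gives 16000 nM in a functional assay on HCT-116 cells (Homo sapiens) for inhibition, read by fluorescence, with a stated time of 48 h; a higher number here means a weaker inhibitor of growth, a lower number a stronger inhibitor of growth.
Compound 2, `CC(C)[C@H](N)C(=O)OCC(C)(C)COC1(c2ccc(Cl)cc2)c2ccccc2C(=O)N1Cc1ccc(Cl)cc1`, gives 11000 nM in this assay.
Compound 3, `CC(C)[C@H](N)C(=O)OCC(C)(C)COC1(c2ccc(Cl)cc2)c2ccccc2C(=O)N1Cc1ccccc1`, gives 20000 nM in this assay.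

Compound 2 and compound 1 differ in one place: 2-(((1-amino-2-methylpropyl)carbonyl)oxy)ethyl in place of 1-((((1-amino-2-methylpropyl)carbonyl)oxy)methyl)-1-methylethyl on a saturated chain carbon bound to an oxygen on a saturated carbon. In this assay this gave a 1.5-fold higher number from compound 2 to compound 1 (0.16 log units; within the scatter). Compound 2 and compound 3 differ in their cores: hydrogen in place of chloro on an aromatic carbon. That change gave a 1.8-fold higher number from compound 2 to compound 3 (0.26 log units; within the scatter). Within the data shown here, no step between compound 1 and compound 3 is counted here; their two values sit close to one another.

Compound 4, `CC(C)[C@H](N)C(=O)OCCCOC1(c2ccc(Cl)cc2)c2ccccc2C(=O)N1Cc1ccccc1`, is not yet measured in this assay. It differs from compound 3 as follows: 2-(((1-amino-2-methylpropyl)carbonyl)oxy)ethyl in place of 1-((((1-amino-2-methylpropyl)carbonyl)oxy)methyl)-1-methylethyl on a saturated chain carbon bound to an oxygen on a saturated carbon. This is the same change already seen between compound 2 and compound 1, made on the other core, where the two cores differ as hydrogen in place of chloro on an aromatic carbon.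

Because a 1.5-fold higher number from compound 2 to compound 1 (0.16 log units; within the scatter) stayed within the scatter, the same change on compound 3 is expected to move the number by a similarly small amount, and the expected step is a 1.4-fold higher number from compound 3 to compound 4 (0.15 log units; within the scatter). Compound 4 is therefore estimated at 28000 nM in this assay. The expected range for compound 4 runs from 14000 nM to 60000 nM, which rests on a single earlier instance of this change and on the weak inhibition shown by compound 3.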

Compound 4, concentration for 50% growth inhibition: 20000 nM
Beside the measured number, compound 4's estimate is 1.4-fold (0.15 log units) above it; the range from low to high includes it.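

In this assay, the 2-(((1-amino-2-methylpropyl)carbonyl)oxy)ethyl chain in place of the 1-((((1-amino-2-methylpropyl)carbonyl)oxy)methyl)-1-methylethyl chain gave no change at the digits printed from compound 3 to compound 4 (within the scatter), and this step agrees with the one seen on the other core: the same change on two cores in this assay, a 1.5-fold higher number (0.16 log units; within the scatter) from compound 2 to compound 1 and no change at the digits printed (within the scatter) from compound 3 to compound 4, 1.5-fold (0.16 log units) apart, within the scatter of two such steps
Hydrogen in place of chloro on an aromatic carbon, now read on the shorter chain, gave a 1.3-fold higher number from compound 1 to compound 4 (0.10 log units; within the scatter), which likewise agrees with the earlier step: the same change on two cores in this assay, a 1.8-fold higher number (0.26 log units; within the scatter) from compound 2 to compound 3 and a 1.3-fold higher number (0.10 log units; within the scatter) from compound 1 to compound 4, 1.5-fold (0.16 log units) apart, within the scatter of two such steps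
Each change thus carries from one core to the other with no difference that can be told from the scatter, but every step among these four compounds lies within the scatter, so this shows only that neither change moved the number measurably here, and it does not show that either change has a real effect that transfers between cores.

The compounds shown leave open whether a longer chain in place of the 2-(((1-amino-2-methylpropyl)carbonyl)oxy)ethyl chain, or a fluoro or methoxy group in place of chloro, would give a step beyond the scatter. They also leave open whether a carboxylic acid in place of the amine would keep the steps this small.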